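Swapping a Methyl for Morpholine on the Carbonyl

This account rests on a few compounds, and the source may have more. Where it says the series, first, only, none or still open, it means among the compounds named here.

Measured so far:
compound 1, `CC#C[C@@H](CC(=O)O)c1ccc(OC[C@H]2COc3ccc(S(C)(=O)=O)cc3O2)cc1`, in a functional assay on HEK293 cells for agonist activity at Free fatty acid receptor 1 (Homo sapiens), read by fluorescence and calcium flux, with a stated time of 10 min (a higher number here means a larger maximal response, a lower number a smaller maximal response), compound 1 gives 55%.
compound 2, `CC#C[C@@H](CC(=O)O)c1ccc(OC[C@H]2COc3ccc(C(C)=O)cc3O2)cc1`, in this assay compound 2 gives 51%.

Among the compounds with values here, of the two numbers, compound 2 has the smaller one, but the only step that connects them, a number 4 percentage points lower from compound 1 to compound 2 (within the scatter), is within the scatter, so the two compounds cannot be told apart on maximal response.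

Compound 3, `CC#C[C@@H](CC(=O)O)c1ccc(OC[C@H]2COc3ccc(C(=O)N4CCOCC4)cc3O2)cc1`, has not been measured. It differs from compound 2 by morpholin-4-yl in place of methyl on a carbonyl carbon. Within the data shown here, the one measured step alters the same group on the shared core. That step stayed within the scatter. There is no measurement of a larger group entering at this carbonyl, so the expectation rests on that single step alone.

For compound 3 the expected step is a number 1 percentage points lower from compound 2 to compound 3 (within the scatter), that is, none beyond the scatter. The estimate for compound 3 is 50%, with a range from 35% to 65%.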

Compound 3, largest response reached (Emax), in percent of the reference or control that the assay uses: 33%
The estimate for compound 3 lay 17 percentage points above the measured number, outside the stated range (below it).
By their numbers in this assay, from the lowest: compound 3; then compounds 2 and 1 (each within the scatter of the next).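

In this assay, morpholin-4-yl in place of methyl on the carbonyl carbon gives a number 18 percentage points lower from compound 2 to compound 3 (beyond the scatter) and so a real loss of maximal response. Against the methylsulfonyl group, (morpholin-4-yl)carbonyl on the same aromatic carbon gives a number 22 percentage points lower from compound 1 to compound 3 (beyond the scatter) and again falls short. Within the data shown here, the earlier change from methylsulfonyl to acetyl stayed within the scatter, so these steps are the first to show that the group at this place can alter how large a response is reached.

Nothing shown here speaks to the reason for this loss. Going by these compounds, it also remains open whether other groups on this carbonyl carbon, such as dimethylamino or piperidin-1-yl, would lower the response in the same way as morpholin-4-yl.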